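The source may report more compounds than this note shows. Statements on the series, on what has been measured and on what is new or still open speak of the compounds shown alone.

In a functional assay on SH-SY5Y cells (Homo sapiens) for cytotoxicity, read by MTT assay, with a stated time of 72 h (on this read-out higher numbers stand for weaker inhibition and lower numbers for stronger inhibition), compound 1 `O=C1c2c[n+]([O-])c3ccccc3c2C(=O)c2c1c1ccccc1n2Cc1cn([C@H]2O[C@H](CO)[C@@H](O)[C@H]2O)nn1` gives 1340 nM, the highest number of the three measured compounds. On the same core but with different chains, compound 2 `O=C1c2c[n+]([O-])c3ccccc3c2C(=O)c2c1c1ccccc1n2CCN1CCCC1` gives 520 nM and compound 3 `O=C1c2c[n+]([O-])c3ccccc3c2C(=O)c2c1c1ccccc1n2CCCCN1CCCCC1` gives 230 nM.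

Compound 4 `O=C1c2c[n+]([O-])c3ccccc3c2C(=O)c2c1c1ccccc1n2Cc1cn([C@H]2C[C@H](O)[C@@H](CO)O2)nn1` has not yet been measured. It differs from compound 1 in one place, on an aromatic nitrogen of a five-membered aromatic ring with 3 nitrogen, where 4-hydroxy-5-(hydroxymethyl)oxolan-2-yl stands in place of 3,4-dihydroxy-5-(hydroxymethyl)oxolan-2-yl (4-hydroxy-5-(hydroxymethyl)oxolan-2-yl in place of 3,4-dihydroxy-5-(hydroxymethyl)oxolan-2-yl on an aromatic nitrogen).

Within the data shown here, no measured step alters this oxolan group. Among the measured compounds shown here, the only measured step, a 2.3-fold lower number from compound 2 to compound 3 (0.35 log units; beyond the scatter), is modest and concerns a different group, so it offers only a rough scale for a change in one place and no direction. No step beyond the usual scatter is therefore expected here. The estimated change is a 1.2-fold lower number from compound 1 to compound 4 (0.09 log units; within the scatter). For compound 4 the estimated value is 1100 nM, with an expected range of 500 nM to 2400 nM.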

Compound 4, half-maximal inhibitory concentration: 620 nM
Compound 4: the middle estimate sits 1.8-fold (0.25 log units) above what was measured; the measured number falls inside the stated range.
By their numbers in this assay, from the lowest: compound 3; then compounds 2 and 4 (each within the scatter of the next); then compound 1.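

Replacing 3,4-dihydroxy-5-(hydroxymethyl)oxolan-2-yl with 4-hydroxy-5-(hydroxymethyl)oxolan-2-yl on the aromatic nitrogen gives, in this assay, a 2.2-fold lower number from compound 1 to compound 4 (0.33 log units; beyond the scatter), so a small edit to this oxolan group can shift the number, though only modestly. The entering group has 8 heavy atoms against 9, 2 hydrogen-bond donors against 3, and 3 defined stereocentres against 4, so several counted features change together in this single step. No measurement available here explains the shift or separates these features.

From the compounds shown here alone, it remains open whether the other hydroxyl groups on the oxolan ring affect the number, and what an amine or a methoxy group would do in their place. Going by these compounds, whether the same exchange would give a similar step with another core or in other cells also remains unknown.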